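The source may hold more compounds than are shown below. What is called first, only, known or untested is meant among the compounds shown, and "the series" means these compounds.

Three compounds built on the shared core of compound 1 `COc1cccc(Nc2nc3cc(Cl)ccc3c(=O)[nH]2)c1` have been examined in an ADME assay on Vero cells (Chlorocebus sabaeus) for cytotoxicity, read by WST assay; on this read-out lower numbers stand for higher toxicity in this test and higher numbers for lower toxicity in this test. In this assay compound 1 gives > 25000 nM, which is a limit of the assay and not a number. Compound 2 `N#Cc1cccc(Nc2nc3cc(Cl)ccc3c(=O)[nH]2)c1` likewise gives > 25000 nM, again a limit. Compound 3 `O=c1[nH]c(Nc2cccc(C(F)(F)F)c2)nc2cc(Cl)ccc12` gives > 25000 nM, also a limit. As a result the steps a step that the two limits leave unreadable from compound 1 to compound 2, a step that the two limits leave unreadable from compound 1 to compound 3 and a step that the two limits leave unreadable from compound 2 to compound 3 cannot be read, since all three values rest at the same limit (the limit of > 25000 nM in this assay, at which 3 of the 3 values shown sit). Compound 3 therefore stands exactly where every measured compound stands, at that limit, with no separation among the three.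

Compound 4 `COC(=O)c1cccc(Nc2nc3cc(Cl)ccc3c(=O)[nH]2)c1` differs from compound 3 by methoxycarbonyl in place of trifluoromethyl on an aromatic carbon. The measured steps that bear on this change are the three exchanges on the same aromatic carbon, none of which could be sized, both ends of each lying at the limit. For the measured compounds named here, with every change at that position so far leaving the limit untouched, no step beyond the scatter is expected here, and the estimated step that the limit leaves unreadable from compound 3 to compound 4 amounts to essentially none. Compound 4 is thus expected to give 30000 nM, in a range from 15000 nM to 60000 nM, with a fair chance that the assay again reports only a limit.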

Compound 4, half-maximal cytotoxic concentration: > 25000 nM
Compound 4 was reported as a limit (the forecaster's own chance of this, stated with the estimate: 75%); the middle value does not contradict the limit.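

Compound 4, like compound 1, compound 2 and compound 3, is reported in this assay only as a limit, so none of its steps to those compounds can be read: the limit of > 25000 nM in this assay, at which 4 of the 4 values shown sit. The compounds shown leave open whether methoxy, cyano, trifluoromethyl and methoxycarbonyl on that aromatic carbon differ at all in this assay, and what would bring a value off the limit.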